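Taking One Methyl Away from Compound 1

The compounds below may be only part of what the source reports. "The series", "measured", "known", "first", "only" and "open" are said of these compounds alone.

Among the measured compounds shown here, in an ADME assay on CCRF-CEM cells (Homo sapiens) for cytotoxicity, with a stated time of 3 days (a lower number here means that less compound is tolerated, a higher number that more compound is tolerated), compound 1 (`Cc1cc(C)cc(Cn2c(=O)cc(C)n(C3C=CC(OC(=O)c4ccccc4)C3)c2=O)c1`) gives 25000 nM as the only actual number in the set. Compound 2 (`Cc1cc(=O)[nH]c(=O)n1C1C=CC(OC(=O)c2ccccc2)C1`) reads > 250000 nM as a limit of the assay. Compound 3 (`O=c1ccn(C2C=CC(O)C2)c(=O)n1Cc1ccccc1`) reads > 250000 nM as a limit too. Compound 4 (`Cc1cc(C)cc(Cn2c(=O)ccn(C3C=CC(OC(=O)c4ccccc4)C3)c2=O)c1`) is compound 1 with hydrogen in place of methyl on an aromatic carbon. For the measured compounds named here, the single measured step (an at least 10-fold higher number from compound 1 to compound 2 (1.00 log units; beyond the scatter)) lies beyond the scatter, but it concerns the 3,5-dimethylbenzyl group and not this methyl. Going by the values given here, no measured step isolates the methyl itself. The expected step (a 1.2-fold higher number from compound 1 to compound 4 (0.08 log units; within the scatter)) is therefore one within the scatter in this assay and no more. Compound 4 is estimated at 30000 nM with an expected range of 12000 nM to 90000 nM for the coming measurement.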

Compound 4, half-maximal cytotoxic concentration: 40000 nM
Estimate against measurement, compound 4: 1.3-fold (0.12 log units) below, within the range that was stated.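

In this assay this methyl now has a step of its own, a 1.6-fold higher number from compound 1 to compound 4 (0.20 log units; within the scatter), so replacing it with hydrogen brings no readable change, whereas the change on the aromatic nitrogen gave an at least 10-fold higher number from compound 1 to compound 2 (1.00 log units; beyond the scatter). Compound 4 still gives a number and not a limit of the assay, so this position stays readable: the limit of > 250000 nM in this assay, at which 2 of the 4 values shown sit.

The compounds shown leave open how an amine or a carboxylic acid on this aromatic carbon would read. They also leave open whether the methyl counts once the 3,5-dimethylbenzyl group is gone.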